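The source may hold more compounds than are shown below. What is called first, only, known or untested is meant among the compounds shown, and "the series" means these compounds.

Compound 3 `O=c1cc(-c2ccccc2Cl)oc2ccc(OCCCCCCN3CCC(O)CC3)cc12` gives 47 nM in an assay on isolated protein (Cavia porcellus) with Sigma non-opioid intracellular receptor 1 (Homo sapiens) as the target, read by radioligand binding (a higher number here means a weaker inhibitor, a lower number a stronger inhibitor), the lowest of the three numbers in hand. Compound 1 `CN(C)CCCCCCOc1ccc2oc(-c3ccccc3)cc(=O)c2c1` gives 432 nM in this assay, and compound 2 `O=c1cc(-c2ccccc2)oc2ccc(OCCCN3CCC(O)CC3)cc12` gives 130 nM. Within the data shown here, the only single-point step available, a 3.3-fold lower number from compound 1 to compound 2 (0.52 log units; beyond the scatter), concerns the amine end of the chain and not the group attached to the shared core. Among the measured compounds shown here, compound 2 and compound 3 differ in two places at once, so their values show only that compound 3 sits lower. Compound 4 `O=c1cc(C2CCCC2)oc2ccc(OCCCCCCN3CCC(O)CC3)cc12` carries the change (cyclopentyl in place of 2-chlorophenyl on an aromatic carbon). For the measured compounds named here, no measured step touches this position, so the series offers no direct precedent for swapping an aromatic ring for a saturated one there. With nothing to lean on, a modest loss is expected rather than a gain, and the uncertainty is wide. For compound 4 a value of 110 nM in this assay is estimated, in the range 30 nM to 400 nM, which corresponds to an expected step of a 2.3-fold higher number from compound 3 to compound 4 (0.37 log units; beyond the scatter).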

Compound 4, half-maximal inhibitory concentration: 51 nM
Estimate against measurement, compound 4: 2.2-fold (0.33 log units) above; the range from low to high includes it.
By their numbers in this assay, from the lowest: compounds 3 and 4 (each within the scatter of the next); then compound 2; then compound 1.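

In this assay, among these compounds, the step of a 1.1-fold higher number from compound 3 to compound 4 (0.04 log units; within the scatter) is the first reading at this position, on an aromatic carbon next to the ring oxygen, and it lies within the scatter. For this one pair, the 2-chlorophenyl group, a six-membered aromatic ring, can give way to cyclopentyl, a five-membered non-aromatic ring without chlorine, with no change beyond the scatter, so an aromatic ring at this position is not required to reach this level. Nothing available bears on why the two groups read alike.

Open, going by these compounds, is how a plain phenyl or a cyclohexyl would read at this position with the same 4-hydroxypiperidin-1-yl chain. Also open, on these data alone, is whether 2-chlorophenyl and cyclopentyl still read alike with a dimethylamino end or a shorter chain.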